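Moving Atoms Within an Amide: What Dose to Expect?

The source may report more compounds than this note shows. Statements on the series, on what has been measured and on what is new or still open speak of the compounds shown alone.

Among the measured compounds shown here, only two numbers are known so far in a functional assay on the whole organism with Mus musculus as the target; on this read-out higher numbers stand for an effect only at larger amounts of compound and lower numbers for an effect already at smaller amounts. There, compound 1 (`CCN(C)C(=O)/C=C1\CCc2c(F)cc(F)cc21`) gives 56 mg/kg and compound 2 (`NC(=O)/C=C1\CCc2ccc(Cl)cc21`) gives 98 mg/kg as its result. These two values lie within the usual scatter of each other, so neither compound can be ranked ahead of the other.

Compound 3 (`CC(C)NC(=O)/C=C1\CCc2c(F)cc(F)cc21`) has not been measured yet. It keeps the core of compound 1 but carries isopropylamino in place of ethyl(methyl)amino on a carbonyl carbon. The two have the same atoms, joined differently.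

For the measured compounds named here, no measured pair of compounds differs in one place only, so the data do not show directly what such a swap does. The estimate therefore starts from compound 1 at 56 mg/kg and leaves room for compound 2 at 98 mg/kg as well. The expected change is a 1.2-fold higher number from compound 1 to compound 3 (0.06 log units; within the scatter) and so no step beyond the scatter in either direction. For compound 3 the estimated dose is 65 mg/kg with an expected range from 25 mg/kg to 150 mg/kg in this measurement.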

Compound 3, dose for half-maximal effect: 50 mg/kg
The estimate for compound 3 lay 1.3-fold (0.11 log units) above the measured number, and the stated range covers the measured number.
By their numbers in this assay, from the lowest: compounds 3, 1 and 2 (each within the scatter of the next).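

Swapping ethyl(methyl)amino for isopropylamino on a carbonyl carbon is the first change here that can be read on its own, and in this assay it comes to a 1.1-fold lower number from compound 1 to compound 3 (0.05 log units; within the scatter) on an otherwise identical compound. At this position, then, rearranging the same four heavy atoms and gaining one hydrogen-bond donor, the amide hydrogen that ethyl(methyl)amino lacks, leaves the two compounds indistinguishable on this read-out. No measurement bears on why the dose shows no clear step, so the result stands as an observation without an explanation.

Going by these compounds, what stays open is whether this position tolerates groups of a different size or kind in the same way, such as a morpholine ring, a longer chain like hexylamino, or a carboxylic acid in place of the amide. Also open, on these data alone, is whether the same swap would read alike on another core, as this single step comes from the core of compound 1 alone and cannot speak for any other.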